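The source may report more compounds than this note shows. Statements on the series, on what has been measured and on what is new or still open speak of the compounds shown alone.

Compound 1, with the structure `CCCCCCCCCCn1c(N)c(N)c(=O)[nH]c1=O`, and compound 2, with the structure `CCCCCCCCCCCCn1c(N)c(N)c(=O)[nH]c1=O`, share one core and differ in a single spot: ethyl in place of hydrogen on a saturated chain carbon, ten or more bonds along the chain from an aromatic nitrogen. In a functional assay (mitochondria, heart) with Bos taurus as the target (a lower number here means a stronger inhibitor, a higher number a weaker inhibitor), compound 1 gives 280 nM, and compound 2 gives 270 nM. The two readings are as good as identical, as a 1.0-fold lower number from compound 1 to compound 2 (0.02 log units; within the scatter) shows, so lengthening the chain at that spot left the inhibition unchanged on this core.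

Compound 3, with the structure `CCCCCCCCCCn1c(=O)[nH]c(=O)c2[nH]c(O)nc21`, rests on a different core. How the core of compound 3 and the core of compound 1 differ is not broken down here. In this assay compound 3 gives 3700 nM, a higher number than either compound 1 or compound 2, and both of those gaps lie beyond the usual scatter.

Compound 4, with the structure `CCCCCCCCCCCCn1c(=O)[nH]c(=O)c2[nH]c(O)nc21`, has not yet been measured. It stands to compound 3 exactly as compound 2 stands to compound 1: the change is ethyl in place of hydrogen on a saturated chain carbon, ten or more bonds along the chain from an aromatic nitrogen, the same change at the same place, only made on the core of compound 3 instead.

In this assay compound 4 is expected to give about 3500 nM, with a likely range from 1500 nM to 8000 nM. That expectation rests on compound 1 and compound 2, where the same change gave a 1.0-fold lower number from compound 1 to compound 2 (0.02 log units; within the scatter). The step from compound 3 is therefore expected to be a 1.1-fold lower number from compound 3 to compound 4 (0.02 log units; within the scatter), a move that would sit inside the ordinary scatter of repeated measurements.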

Compound 4, half-maximal inhibitory concentration: 1600 nM
The estimate for compound 4 lay 2.2-fold (0.34 log units) above the measured number; low and high end bracket the measured number.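

On the core of compound 3, putting ethyl in place of hydrogen on a saturated chain carbon, ten or more bonds along the chain from an aromatic nitrogen, gave a modest but real shift toward stronger inhibition in this assay: a 2.3-fold lower number from compound 3 to compound 4 (0.36 log units; beyond the scatter). Although this step lies beyond the scatter and the matching step on the core of compound 1 does not, the two steps cannot be told apart when set side by side: the same change on two cores in this assay, a 1.0-fold lower number (0.02 log units; within the scatter) from compound 1 to compound 2 and a 2.3-fold lower number (0.36 log units; beyond the scatter) from compound 3 to compound 4, 2.2-fold (0.35 log units) apart, within the scatter of two such steps. This shows that, in these two pairs, the change carries from one core to the other without a measurable difference in its effect, and that it did not weaken inhibition on either core; it does not show that the effect is truly identical on both cores, nor that it would hold on any third core, since two pairs are too few to support a general rule.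

The compounds shown leave open how a longer chain would behave on either core, and whether inhibition would keep moving in the same direction or level off. They also leave open what would happen if an amine or a carboxylic acid took the place of the ethyl at this spot.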